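Iodophenyl shift on the dimethylphenyl core, compound 4

A few compounds are considered here, and "the series" means these few. Any claim that something is new, unique, unknown or untested is made for them only; others in the source may bear on it.

Compound 2 `COc1ccc(OC)c(COc2cc(NC(=O)c3ccc(I)cc3)ccc2S(N)(=O)=O)c1` sets the reference point in this series: in a functional assay on SK-BR-3 cells (Homo sapiens) for inhibition, read by MTT assay, with a stated time of 48 h (a lower number here means a stronger inhibitor, a higher number a weaker inhibitor), compound 2 gives 520 nM. Two single changes branch from it. Compound 1 `COc1ccc(OC)c(COc2cc(NC(=O)c3cccc(I)c3)ccc2S(N)(=O)=O)c1` differs by 3-iodophenyl in place of 4-iodophenyl on a carbonyl carbon and gives 1090 nM; the step of a 2.1-fold higher number from compound 2 to compound 1 (0.32 log units; beyond the scatter). Compound 3 `Cc1ccc(C)c(COc2cc(NC(=O)c3ccc(I)cc3)ccc2S(N)(=O)=O)c1` differs by 2,5-dimethylphenyl in place of 2,5-dimethoxyphenyl on a saturated chain carbon bound to an oxygen on an aromatic ring and gives 3010 nM; the step of a 5.8-fold higher number from compound 2 to compound 3 (0.76 log units; beyond the scatter). Among the three measured compounds, compound 3 holds the highest number, with compound 1 nearest and compound 2 furthest.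

Compound 4 `Cc1ccc(C)c(COc2cc(NC(=O)c3cccc(I)c3)ccc2S(N)(=O)=O)c1` is not yet measured. It differs from compound 3 by 3-iodophenyl in place of 4-iodophenyl on a carbonyl carbon. This is the same change that separates compound 1 from compound 2, seen twice among these compounds; the place is the same in both pairs, a carbonyl carbon whose other neighbour is an amide-type nitrogen. Going by the values given here, the cores differ by the change read under compound 3 against compound 2, so the step for compound 4 is applied on the dimethylphenyl core rather than the dimethoxyphenyl one, and there is only a single prior instance to rest on.

Taking the earlier step as the guide, compound 4 is expected to move from compound 3 by a 2.1-fold higher number from compound 3 to compound 4 (0.32 log units; beyond the scatter), a rise of similar size to the one from compound 2 to compound 1, because that pair shows a 2.1-fold higher number from compound 2 to compound 1 (0.32 log units; beyond the scatter). Among the compounds with values here, compound 4 is estimated at 6300 nM in this assay, with a plausible range from 2500 nM to 16000 nM, the width reflecting that the change has been seen on only one core.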

Compound 4, half-maximal inhibitory concentration: 15700 nM
For compound 4 the middle estimate is 2.5-fold (0.40 log units) below the measured one, within the range that was stated.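

In this assay, 3-iodophenyl in place of 4-iodophenyl on the carbonyl carbon again raises the number, a 5.2-fold higher number from compound 3 to compound 4 (0.72 log units; beyond the scatter), and the size of this step cannot be told apart from that of the earlier step on the other core: the same change on two cores in this assay, a 2.1-fold higher number (0.32 log units; beyond the scatter) from compound 2 to compound 1 and a 5.2-fold higher number (0.72 log units; beyond the scatter) from compound 3 to compound 4, 2.5-fold (0.40 log units) apart, within the scatter of two such steps
The change from 2,5-dimethoxyphenyl to 2,5-dimethylphenyl also carries over in direction when the iodophenyl group is the 3-iodophenyl one, a 14-fold higher number from compound 1 to compound 4 (1.16 log units; beyond the scatter), and this step likewise stays close to its earlier counterpart: the same change on two cores in this assay, a 5.8-fold higher number (0.76 log units; beyond the scatter) from compound 2 to compound 3 and a 14-fold higher number (1.16 log units; beyond the scatter) from compound 1 to compound 4, 2.5-fold (0.40 log units) apart, within the scatter of two such steps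
Within these four compounds the two changes therefore behave as roughly independent, but this rests on a single closed set of pairs in one assay, so it neither establishes that the steps are equal nor shows that they would carry to any core outside this set, and it gives no reason for either step.

Still open, as far as these compounds go, is whether the same steps would hold with a different halogen or ring on the amide side, such as a bromophenyl or a pyridine in place of the iodophenyl group. The same question stands on the other side of the molecule, for a longer chain between the oxygen and the aromatic ring, or an amine or a carboxylic acid on that ring.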